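Oxadiazole substituent change in a weak pyrimidine series

A few compounds are considered here, and "the series" means these few. Any claim that something is new, unique, unknown or untested is made for them only; others in the source may bear on it.

Measured so far in a functional assay on KG-1a cells (Homo sapiens) for inhibition, read by MTT assay, with a stated time of 72 h; a higher number here means a weaker inhibitor, a lower number a stronger inhibitor:
compound 1 `Cc1ccc(-n2cc(C(C)O)nn2)cc1Nc1nccc(-c2cccnc2)n1` gives 12700 nM
compound 2 `Cc1ccc(-c2nnc(-c3cccnc3)o2)cc1Nc1nccc(-c2cccnc2)n1` gives > 30000 nM

Compound 2 sits at the limit of > 30000 nM in this assay, at which 1 of the 2 values shown sits, so its value is a limit of the assay and not a number. Among the measured compounds shown here, compound 1 is the only compound with a measured number, and it is a weak inhibitor. Compound 3 is `Cc1nnc(-c2ccc(C)c(Nc3nccc(-c4cccnc4)n3)c2)o1`; it differs from compound 2 by methyl in place of pyridin-3-yl on an aromatic carbon. For the measured compounds named here, no step between two measured compounds is available, so the size of this change in this assay can be read only from the position of compound 2 at the limit. The expected step is an at least 1.2-fold lower number from compound 2 to compound 3 (0.07 log units; that floor lies within the scatter), hardly beyond the scatter, with a real chance that compound 3 again returns only a limit rather than a number. Compound 3 is expected to give 25000 nM, within 10000 nM to 60000 nM.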

Compound 3, half-maximal inhibitory concentration: 18000 nM
Estimate against measurement, compound 3: 1.4-fold (0.14 log units) above; the measured number falls inside the stated range.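

In this assay, methyl in place of pyridin-3-yl on the five-membered aromatic ring with 2 nitrogen and 1 oxygen yields a measured number, and an at least 1.6-fold lower number from compound 2 to compound 3 (0.22 log units; that floor lies within the scatter) is the step for this change. Putting 5-methyl-1,3,4-oxadiazol-2-yl in place of 4-(1-hydroxyethyl)-1H-1,2,3-triazol-1-yl on the aromatic carbon gives a 1.4-fold higher number from compound 1 to compound 3 (0.15 log units; within the scatter) as its step, so these two groups are not told apart in this assay. The value of compound 2 is a limit and not a number, so the full size of the methyl step stays unknown: the limit of > 30000 nM in this assay, at which 1 of the 3 values shown sits.

From the compounds shown here alone, whether an amine, a carboxylic acid or a longer alkyl chain at this position would move the number beyond the scatter remains open. Also open, going by these compounds, is whether any group here can lift the series out of its weak range.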